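The source may hold more compounds than are shown below. What is called first, only, known or untested is meant among the compounds shown, and "the series" means these compounds.

Measured compounds:
compound 1 `O=C(N/N=C/c1ccc(Br)cc1)N1CCc2ncnc(Nc3ccc(F)c(Cl)c3)c2C1`, > 200000 nM in a functional assay on NCI-H1975 cells (Homo sapiens) for cytotoxicity, read by MTT assay, with a stated time of 72 h; a lower number here means a stronger inhibitor, a higher number a weaker inhibitor;
compound 2 `O=C(N/N=C/c1ccc(F)cc1)N1CCc2ncnc(Nc3ccc(F)c(Cl)c3)c2C1`, 64500 nM in this assay;
compound 3 `O=C(N/N=C/c1ccc(Br)cc1)N1CCc2ncnc(Nc3cccc(C(F)(F)F)c3)c2C1`, 61400 nM in this assay.

For compound 1 the value > 200000 nM is a limit of the assay, not a number; it is the limit of > 200000 nM in this assay, at which 1 of the 3 values shown sits. The change fluoro in place of bromo on an aromatic carbon gives an at least 3.1-fold lower number from compound 1 to compound 2 (0.49 log units; beyond the scatter). This step is open-ended: compound 1, its starting point, sits at a limit. The two cores differ by 3-(trifluoromethyl)phenyl in place of 3-chloro-4-fluorophenyl on a nitrogen on an aromatic ring, with an at least 3.2-fold lower number from compound 1 to compound 3 (0.51 log units; beyond the scatter). Compound 4 `O=C(N/N=C/c1ccc(F)cc1)N1CCc2ncnc(Nc3cccc(C(F)(F)F)c3)c2C1` is not yet measured; it differs from compound 3 by fluoro in place of bromo on an aromatic carbon, the same change as from compound 1 to compound 2, at the same place. Beside an at least 3.1-fold lower number from compound 1 to compound 2 (0.49 log units; beyond the scatter), the expected step is a 2.5-fold lower number from compound 3 to compound 4 (0.39 log units; beyond the scatter), taken as a modest gain since the earlier step is only a lower bound read from a limit. Compound 4 is expected near 25000 nM, estimated between 8000 nM and 80000 nM.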

Compound 4, half-maximal inhibitory concentration: 55600 nM
Compound 4: middle estimate off by 2.2-fold (0.35 log units), on the low side, within the range that was stated.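

On the core of compound 3, fluoro in place of bromo gives a 1.1-fold lower number from compound 3 to compound 4 (0.04 log units; within the scatter), so this change does not carry over at the size seen on the core of compound 1: the same change on two cores in this assay, an at least 3.1-fold lower number (0.49 log units; beyond the scatter) from compound 1 to compound 2 and a 1.1-fold lower number (0.04 log units; within the scatter) from compound 3 to compound 4, at least 2.8-fold (0.44 log units) apart, beyond the scatter of two such steps. The swap to 3-(trifluoromethyl)phenyl from 3-chloro-4-fluorophenyl gives a 1.2-fold lower number from compound 2 to compound 4 (0.06 log units; within the scatter), which also stands apart from the step on the bromo compounds: the same change on two cores in this assay, an at least 3.2-fold lower number (0.51 log units; beyond the scatter) from compound 1 to compound 3 and a 1.2-fold lower number (0.06 log units; within the scatter) from compound 2 to compound 4, at least 2.8-fold (0.44 log units) apart, beyond the scatter of two such steps. As far as these compounds go, both earlier steps start from compound 1, whose value is a limit and not a number, so their true size remains unknown, and two cores set no rule for the series: the limit of > 200000 nM in this assay, at which 1 of the 4 values shown sits.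

Open, from the compounds shown here alone, is whether an amine or a carboxylic acid in place of fluoro on that aromatic carbon would move the number beyond the scatter on either core. Also open, going by these compounds, is whether 3-ethynylphenyl on the nitrogen would follow either pattern.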